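Second chloro on the shared core: expected effect

The compounds below may be only part of what the source reports. "The series", "measured", "known", "first", "only" and "open" are said of these compounds alone.

Going by the values given here, compound 1 `ClCc1ccc(Cn2cnc3c(Cl)ncnc32)cc1` stands lowest of the two numbers measured so far: in a functional assay on SF-295 cells (Homo sapiens) for cytotoxicity, read by sulforhodamine B assay, with a stated time of 48 h (on this read-out higher numbers stand for weaker inhibition of growth and lower numbers for stronger inhibition of growth), compound 1 gives 270 nM. Compound 2 `ClCc1cccc(Cn2cnc3c(Cl)nc(Cl)nc32)c1` gives 4360 nM in this assay, a gap beyond the scatter; compound 2 differs from compound 1 in more than one place, so only the two values themselves are noted. Compound 3 `ClCc1ccc(Cn2cnc3c(Cl)nc(Cl)nc32)cc1` carries chloro in place of hydrogen on an aromatic carbon, between two ring nitrogen atoms of the shared core. Among the compounds with values here, no single-change step is available, so the change is expected to bring a moderate loss, a 2.2-fold higher number from compound 1 to compound 3 (0.35 log units; beyond the scatter). Compound 3 is therefore estimated at 600 nM, within a range from 150 nM to 2500 nM.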

Compound 3, concentration for 50% growth inhibition: 7240 nM
For compound 3 the middle estimate is 12-fold (1.08 log units) below the measured one; measured number above the stated range.
By their numbers in this assay, from the lowest: compound 1; then compounds 2 and 3 (each within the scatter of the next).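

In this assay, going by these compounds alone, chloro in place of hydrogen on an aromatic carbon, between two ring nitrogen atoms of the shared core, gives a 27-fold higher number from compound 1 to compound 3 (1.43 log units; beyond the scatter) as the first single-change step. At this position, this one replacement is enough for a large loss, and hydrogen is clearly the better of the two groups. Nothing available accounts for the size of this loss. As far as these compounds go, whether the loss is specific to chloro remains open, as an amine or a methoxy group on the same carbon would test that.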